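The source may hold more compounds than are shown below. What is called first, only, known or untested is meant among the compounds shown, and "the series" means these compounds.

Compound 1 `Cc1nc(C)c(C(=O)Oc2ccccc2/C=C/C(=O)O)nc1C`, compound 2 `COc1ccc(OC(=O)c2nc(C)c(C)nc2C)c(/C=C/C(=O)O)c1` and compound 3 `CCOC(=O)/C=C/c1cc(OC)c(OC(=O)c2nc(C)c(C)nc2C)c(OC)c1` have been tested for their effect on cell viability. In a functional assay on EA.hy 926 cells (Homo sapiens) for cytotoxicity, read by MTT assay, with stated times of 24 h and 12 h, tested at 25 uM (on this read-out lower numbers stand for a weaker effect and higher numbers for a stronger effect at the one concentration tested), compound 1 gives 61.8%, compound 2 gives 45% and compound 3 gives 20.9%. The difference between the cores of compound 2 and compound 3 is not broken down here. One change, however, is seen twice. From compound 2 to compound 1 the change is hydrogen in place of methoxy on an aromatic carbon, and in this assay it makes a number 16.8 percentage points higher from compound 2 to compound 1 (beyond the scatter). The same kind of change separates compound 3 from compound 4 `CCOC(=O)/C=C/c1ccc(OC(=O)c2nc(C)c(C)nc2C)c(OC)c1`: hydrogen in place of methoxy on an aromatic carbon. Its surroundings differ, though: in compound 1 the change sits meta to a 2-carboxyethenyl group and para to a large group, whereas in compound 4 it sits ortho to a large group, meta to a 2-(ethoxycarbonyl)ethenyl group and meta to a methoxy group. Resting on the step from compound 2 to compound 1 and on the value of compound 3 20.9%, a similar rise is expected for compound 4, namely a number 15.1 percentage points higher from compound 3 to compound 4 (beyond the scatter) in this assay. Compound 4 is therefore estimated at 36%, between 22% and 52%.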

Compound 4, a percentage reported as activity, at one concentration (the size of the read-out at that concentration, not a potency): 53.3%
For compound 4 the middle estimate is 17.3 percentage points below the measured one, and the stated range ends below it.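

In this assay replacing the methoxy group with hydrogen gives a number 32.4 percentage points higher from compound 3 to compound 4 (beyond the scatter), so the number rises on both cores, but the size of the step does not carry over from one core to the other: the same change on two cores in this assay, a number 16.8 percentage points higher (beyond the scatter) from compound 2 to compound 1 and a number 32.4 percentage points higher (beyond the scatter) from compound 3 to compound 4, 15.6 percentage points apart, beyond the scatter of two such steps. The direction is therefore shared by these two pairs, while the step measured on one core would not have given the size of the step on the other. The two pairs do not show which difference between the cores sets the steps apart, since the change in compound 4 sits meta to a 2-(ethoxycarbonyl)ethenyl group and meta to a methoxy group, and two pairs make no general rule for the series.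

The compounds shown leave open whether the larger step goes with the ethyl ester or with the second methoxy group, as no pair here separates the two. They also leave open how a hydroxy group, an amine or a fluorine atom at the same place would compare with hydrogen and methoxy.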